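The compounds below may be only part of what the source reports. "The series", "measured", "known", "first", "only" and "open" are said of these compounds alone.

In an in vitro ADME assay on microsomes from liver (Homo sapiens) for metabolic stability (a lower number here means slower removal, a higher number faster removal of the compound), compound 1 `Cc1ccc(C(=O)N2CCC(=CC(=O)N[C@@H]3CCN(Cc4ccc5cc(F)ccc5c4)C3)CC2)c(O)c1` gives 156 mL/min/kg, and compound 3 `COc1ccc(O)c(C(=O)N2CCC(=CC(=O)N[C@@H]3CCN(Cc4ccc5cc(F)ccc5c4)C3)CC2)c1` gives 119 mL/min/kg. These two numbers lie level, with a 1.3-fold lower number from compound 1 to compound 3 (0.12 log units; within the scatter). Compound 2 `O=C(C=C1CCN(C(=O)c2ccccc2O)CC1)N[C@@H]1CCN(Cc2ccc3cc(F)ccc3c2)C1` gives only a limit, < 64 mL/min/kg.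

Compound 4 `COc1ccc(C(=O)N2CCC(=CC(=O)N[C@@H]3CCN(Cc4ccc5cc(F)ccc5c4)C3)CC2)c(O)c1` swaps one group of compound 1, with methoxy in place of methyl on an aromatic carbon. Two further steps bear on this swap. Hydrogen in place of methyl gave an at least 2.4-fold lower number from compound 1 to compound 2 (0.38 log units; beyond the scatter), while methoxy in place of hydrogen gave an at least 1.8-fold higher number from compound 2 to compound 3 (0.26 log units; that floor lies within the scatter). Compound 3 also carries a methoxy group, and at 119 mL/min/kg it stays within the scatter of compound 1. A step within the scatter is therefore expected: a 1.4-fold lower number from compound 1 to compound 4 (0.13 log units; within the scatter). Compound 4 is estimated at 115 mL/min/kg, with an expected range of 65 mL/min/kg to 190 mL/min/kg.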

Compound 4, clearance: 232 mL/min/kg
For compound 4 the middle estimate is 2.0-fold (0.30 log units) below the measured one, and the stated range ends below it.
By their numbers in this assay, from the lowest: compounds 3, 1 and 4 (each within the scatter of the next). At a limit, below all of these: compound 2.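

In this assay, methoxy in place of methyl, on the carbon para to a large group, makes no change beyond the scatter, with a 1.5-fold higher number from compound 1 to compound 4 (0.17 log units; within the scatter). Shifting the methoxy, giving 2-hydroxy-4-methoxyphenyl in place of 2-hydroxy-5-methoxyphenyl, also stays within the scatter, with a 1.9-fold higher number from compound 3 to compound 4 (0.29 log units; within the scatter). Only the comparison with hydrogen at this position clears the scatter, with an at least 3.6-fold higher number from compound 2 to compound 4 (0.55 log units; beyond the scatter), and that step rests on a limit of the assay: the limit of < 64 mL/min/kg in this assay, at which 1 of the 4 values shown sits.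

From the compounds shown here alone, how far compound 2 truly lies from the others stays open. So does what a chlorine atom, an amine or a longer chain would give at this position.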